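Adding hydroxy to the phenyl of compound 3

The compounds below may be only part of what the source reports. "The series", "measured", "known", "first", "only" and "open" are said of these compounds alone.

In a functional assay on HeLa cells (Homo sapiens) for inhibition, with a stated time of 72 h (a lower number here means a stronger inhibitor, a higher number a weaker inhibitor), compound 1 `NC1CCC(Nc2nc(NCc3ccc(-c4ccccc4)cc3)c3ncn(C4CCCC4)c3n2)CC1` gives 240 nM, compound 2 `NC1CCC(Nc2nc(NCc3ccc(-c4ccsc4)cc3)c3ncn(C4CCCC4)c3n2)CC1` gives 220 nM and compound 3 `NC1CCC(Nc2nc(NCc3ccc(-c4ccccc4)nc3)c3ncn(C4CCCC4)c3n2)CC1` gives 114 nM. Compound 3 stands apart from compound 1, with a 2.1-fold lower number from compound 1 to compound 3 (0.32 log units; beyond the scatter), but not from compound 2, with a 1.9-fold lower number from compound 2 to compound 3 (0.29 log units; within the scatter). Compound 4 `NC1CCC(Nc2nc(NCc3ccc(-c4ccccc4O)nc3)c3ncn(C4CCCC4)c3n2)CC1` has hydroxy in place of hydrogen on an aromatic carbon. For the measured compounds named here, no measured step adds such a group. The closest measured change replaces phenyl with thiophen-3-yl, with a 1.1-fold lower number from compound 1 to compound 2 (0.04 log units; within the scatter). On that single precedent, no step beyond the scatter is expected in this assay, and no firm direction can be given. The estimated step is a 1.1-fold lower number from compound 3 to compound 4 (0.06 log units; within the scatter). For compound 4 the expected value is 100 nM, within an estimated range of 35 nM to 280 nM.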

Compound 4, half-maximal inhibitory concentration: 16 nM
Beside the measured number, compound 4's estimate is 6.3-fold (0.80 log units) above it; measured number outside the range, below it.
By their numbers in this assay, from the lowest: compound 4; then compounds 3, 2 and 1 (each within the scatter of the next, the first and the last beyond it).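

For the compounds shown here, the change from phenyl to 2-hydroxyphenyl gives a 7.1-fold lower number from compound 3 to compound 4 (0.85 log units; beyond the scatter) in this assay and is the largest step so far. The earlier changes at this end of the molecule gave much smaller steps, whereas a single hydroxy ortho to a large group moves the number well beyond the scatter. Nothing available explains this step.

Going by these compounds, whether the hydroxy itself is required remains open, as a methoxy or an amine on the same carbon would test this. It is also unknown whether hydroxy has a similar effect on the thiophen-3-yl of compound 2.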